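Chlorophenyl positional isomers on a shared hydroxyphenyl core

The compounds below may be only part of what the source reports. "The series", "measured", "known", "first", "only" and "open" are said of these compounds alone.

Measured compounds:
compound 1, `Oc1cccc(-c2cc(-c3ccncc3)nc(-c3cccc(Cl)c3)c2)c1`, in an ADME assay on HEK293 cells (Homo sapiens) for cytotoxicity, read by CCK-8 assay and cell counting, with a stated time of 2 days (a lower number here means a stronger inhibitor, a higher number a weaker inhibitor), compound 1 gives "not determined" (no result reported)
compound 2, `Oc1cccc(-c2cc(-c3cccc(Cl)c3)nc(-c3ccco3)c2)c1`, this assay 2530 nM
compound 3, `Oc1cccc(-c2cc(-c3ccccc3)nc(-c3ccccc3Cl)c2)c1`, this assay 1760 nM

Compound 3 has the lower of the two numbers reported, but the gap to compound 2 is within the scatter, so no order can be drawn between them. Compound 1 carries no number.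

Compound 4, `Oc1cccc(-c2cc(-c3ccccc3)nc(-c3cccc(Cl)c3)c2)c1`, has the same atoms as compound 3 joined differently: 3-chlorophenyl in place of 2-chlorophenyl on an aromatic carbon. Within the data shown here, no step between measured compounds shows what moving the chlorine within that ring does here, so no direction beyond the scatter is anticipated; the step of a 1.1-fold higher number from compound 3 to compound 4 (0.06 log units; within the scatter) is expected to stay within the scatter. For compound 4 the estimate in this assay is 2000 nM, with a range from 900 nM to 4500 nM.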

Compound 4, half-maximal inhibitory concentration: 3120 nM
For compound 4 the middle estimate is 1.6-fold (0.19 log units) below the measured one; the range from low to high includes it.
By their numbers in this assay, from the lowest: compounds 3, 2 and 4 (each within the scatter of the next).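

In this assay, 3-chlorophenyl in place of 2-chlorophenyl next to the ring nitrogen gives a 1.8-fold higher number from compound 3 to compound 4 (0.25 log units; within the scatter), so these two chlorine placements cannot be told apart here. Phenyl in place of furan-2-yl gives a 1.2-fold higher number from compound 2 to compound 4 (0.09 log units; within the scatter), so with 3-chlorophenyl in place, those two groups cannot be told apart either. No available measurement accounts for either step.

Open, from the compounds shown here alone, is whether an amine or a carboxylic acid on the chlorophenyl ring would give a step beyond the scatter. Also open, going by these compounds, is whether a methoxy group in place of the chlorine would do so.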